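Notes on the secondary amine pair, bromo to fluoro

The source may report more compounds than this note shows. Statements on the series, on what has been measured and on what is new or still open speak of the compounds shown alone.

Compound 2 `COc1ccc(CNc2cc(OC)c(OC)c(OC)c2)cc1Br` gives the highest number of the three measured in a functional assay on HCT-116 cells (Homo sapiens) for inhibition, read by MTT assay, with a stated time of 48 h (a lower number here means a stronger inhibitor, a higher number a weaker inhibitor), at 48100 nM. Within the data shown here, compound 3 `C/C=C/C(=O)N(Cc1ccc(OC)c(Br)c1)c1cc(OC)c(OC)c(OC)c1` gives 2800 nM in this assay, and the acylation from compound 2 to compound 3 is the only measured step: a 17-fold lower number from compound 2 to compound 3 (1.23 log units; beyond the scatter). Compound 1 `COc1ccc(CN(C(=O)C2CC2)c2cc(OC)c(OC)c(OC)c2)cc1O` gives 49 nM in this assay, but it differs from compound 2 in more than one place, so only its value is known.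

Compound 4 `COc1ccc(CNc2cc(OC)c(OC)c(OC)c2)cc1F` differs from compound 2 by fluoro in place of bromo on an aromatic carbon. Among the measured compounds shown here, no measured step touches this halogen exchange; the nitrogen stays unacylated, as in compound 2. The expected step of a 1.2-fold lower number from compound 2 to compound 4 (0.08 log units; within the scatter) is therefore none beyond the scatter. Compound 4 is estimated at 40000 nM in this assay, with a range from 15000 nM to 120000 nM.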

Compound 4, half-maximal inhibitory concentration: 32200 nM
Beside the measured number, compound 4's estimate is 1.2-fold (0.09 log units) above it, within the range that was stated.
By their numbers in this assay, from the lowest: compound 1; then compound 3; then compounds 4 and 2 (each within the scatter of the next).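

In this assay, the halogen on the aromatic carbon ortho to a methoxy group now has a measured exchange: fluoro in place of bromo gives a 1.5-fold lower number from compound 2 to compound 4 (0.17 log units; within the scatter) on the unacylated nitrogen, so this change does not separate the two halogens. By contrast, acylation gives a 17-fold lower number from compound 2 to compound 3 (1.23 log units; beyond the scatter) and lies beyond the scatter. No available evidence explains either step.

As far as these compounds go, whether the halogen exchange stays within the scatter on an acylated nitrogen, as in compound 3, remains open. So does the effect of a nitrile or an amine at this position.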